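This account rests on a few compounds, and the source may have more. Where it says the series, first, only, none or still open, it means among the compounds named here.

In an ADME assay on microsomes from liver (Mus musculus) for metabolic stability, read by LC-MS, with a stated time of 30 min, tested at 1 uM (a higher number here means that more of the compound is left, a lower number that less of the compound is left), compound 3 `CC[C@@H]1CC[C@@H](C(=O)N2CCN(C)[C@@H](C)C2)N1C(=O)C1=C(C(C)C)N2C(=N[C@@](C)(c3ccc(Cl)cc3)[C@H]2c2ccc(Cl)cc2)S1` stands highest of the three measured compounds with 69% remaining after incubation. Compound 1 `CC[C@@H]1CC[C@@H](C(=O)N2CCN(C(C)=O)CC2)N1C(=O)C1=C(C(C)C)N2C(=N[C@@](C)(c3ccc(Cl)cc3)[C@H]2c2ccc(Cl)cc2)S1` gives 38% in the same test and compound 2 `CC[C@@H]1CC[C@@H](C(=O)N2CCOCC2)N1C(=O)C1=C(C(C)C)N2C(=N[C@@](C)(c3ccc(Cl)cc3)[C@H]2c2ccc(Cl)cc2)S1` gives 6% there. Compound 4 `CC[C@@H]1CC[C@@H](C(=O)N2CCN(C(C)=O)[C@@H](C)C2)N1C(=O)C1=C(C(C)C)N2C(=N[C@@](C)(c3ccc(Cl)cc3)[C@H]2c2ccc(Cl)cc2)S1` differs from compound 3 at one place: acetyl in place of methyl on an amine nitrogen in a ring is acetyl in place of methyl on an amine nitrogen in a ring. The closest evidence is a number 31 percentage points higher from compound 1 to compound 3 (beyond the scatter) on going from 4-acetylpiperazin-1-yl to 3,4-dimethylpiperazin-1-yl. Within the data shown here, that large step also adds the ring methyl group that compound 4 keeps, and no measured pair separates the two changes. The steps of a number 32 percentage points lower from compound 1 to compound 2 (beyond the scatter) and a number 63 percentage points higher from compound 2 to compound 3 (beyond the scatter) show that changes at this amide group can move the read-out widely. With its acetyl group, compound 4 is expected to fall near compound 1 rather than compound 3. A large downward change is therefore expected, namely a number 27 percentage points lower from compound 3 to compound 4 (beyond the scatter) beyond the scatter. Compound 4 is estimated at 42% within an expected range from 22% to 62% in this test.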

Compound 4, percent of the compound remaining: 54%
The estimate for compound 4 lay 12 percentage points below the measured number, and the stated range covers the measured number.
By their numbers in this assay, from the lowest: compound 2; then compound 1; then compound 4; then compound 3.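

In this assay, among these compounds, compound 3 and compound 4 isolate the group on the amine nitrogen in a ring, which no earlier pair could do: acetyl in place of methyl gives a number 15 percentage points lower from compound 3 to compound 4 (beyond the scatter) and is a modest change. The ring methyl group is now separated too, as methyl in place of hydrogen on a saturated ring carbon gives a number 16 percentage points higher from compound 1 to compound 4 (beyond the scatter), so each single change accounts for part of the gap between compound 1 and compound 3, while the larger exchange of morpholin-4-yl gives a number 48 percentage points higher from compound 2 to compound 4 (beyond the scatter). Nothing available here explains why any of these changes moves the read-out.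

The compounds shown leave open whether a propanoyl or a methanesulfonyl group on that nitrogen would behave like acetyl or like methyl. They also leave open whether an ethyl group could replace the ring methyl group, and whether a methyl group on the morpholine ring would change the read-out.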